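The compounds below may be only part of what the source reports. "The series", "measured", "known", "first", "only" and "open" are said of these compounds alone.

Of the compounds shown here, three share a core and have been tested in an assay on isolated protein for binding affinity to corticotropin-releasing factor receptor 1 (Homo sapiens); on this read-out higher numbers stand for weaker inhibition and lower numbers for stronger inhibition. Compound 1, `CCN(CC)c1cc(C)nc(N(CC)c2ccc(C(C)=O)cc2Br)n1`, gives 5 nM. Compound 2, `CCCCN(CC#N)c1nc(C)nc(N(CC)c2ccc(N(C)C)cc2C(F)(F)F)n1`, gives 6 nM. Compound 3, `CCCCN(CC)c1nc(C)nc(N(CC)c2ccc(OC(F)(F)F)cc2Br)n1`, gives 5 nM. Compound 2 has the highest of the three numbers, but its distance to compound 1 and to compound 3 lies within the scatter, so the three cannot be ranked. Compound 4, `CCN(CC)c1nc(C)nc(N(CC)c2ccc(N(C)C)cc2C(F)(F)F)n1`, has not yet been measured in this assay. It differs from compound 2 in one place: diethylamino in place of butyl(cyanomethyl)amino on an aromatic carbon. Among the measured compounds shown here, no step between measured compounds matches this change. Compound 1 also carries a diethylamino group and is as potent as compound 2, so the step of no change at the digits printed from compound 2 to compound 4 (within the scatter) is expected to stay within the scatter. Compound 4 is therefore expected to give 6 nM, within the range 2 nM to 20 nM.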

Compound 4, inhibition constant: 20 nM
Estimate against measurement, compound 4: 3.3-fold (0.52 log units) below, and the stated range covers the measured number.
By their numbers in this assay, from the lowest: compounds 1, 3 and 2 (each within the scatter of the next); then compound 4.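

Among the compounds shown here, this is the first comparison in the set that changes only one place, and it shows that the group on this aromatic carbon, between two ring nitrogen atoms, affects binding. Diethylamino in place of butyl(cyanomethyl)amino gives a 3.3-fold higher number from compound 2 to compound 4 (0.52 log units; beyond the scatter), a modest weakening. Nothing measured here explains this step.

Since the butyl chain and the cyanomethyl arm leave together, the compounds shown cannot separate their contributions. Also open, going by these compounds, is how a group such as dipropylamino or morpholine would behave at this position.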